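This account rests on a few compounds, and the source may have more. Where it says the series, first, only, none or still open, it means among the compounds named here.

In a functional assay (aorta) with Oryctolagus cuniculus as the target (a lower number here means tighter binding, a higher number weaker binding), compound 1 `COc1cc(OCCCN2CCC(C(c3ccc(F)cc3)c3ccc(F)cc3)CC2)ccc1C(C)=O` gives 3.16 nM, while compound 2 `NC(=O)c1ccc(OCCCN2CCC(C(c3ccc(F)cc3)c3ccc(F)cc3)CC2)cc1` gives 31.6 nM, the higher of the two numbers and thus the weaker binding. Compound 3 `Fc1ccc(OCCCN2CCC(C(c3ccc(F)cc3)c3ccc(F)cc3)CC2)cc1` differs from compound 2 in one place: fluoro in place of carbamoyl on an aromatic carbon. Fluoro takes the place of carbamoyl on an aromatic carbon, para to a large group. Going by the values given here, only one measured step bears on this change, and it is an indirect guide, since no fluoro compound has been measured yet: a 10-fold higher number from compound 1 to compound 2 (1.00 log units; beyond the scatter). That step shows that replacing the group on the oxygen-linked ring can shift the number beyond the scatter, and that the carbamoyl compound ended up higher. A modest fall is therefore expected rather than a rise, though with wide uncertainty. The expected change is a 2.6-fold lower number from compound 2 to compound 3 (0.42 log units; beyond the scatter). For compound 3 the estimated value is 12 nM, with a likely range from 3 nM to 50 nM.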

Compound 3, dissociation constant: 1.26 nM
Compound 3: middle estimate off by 9.5-fold (0.98 log units), on the high side, and the stated range ends above it.
By their numbers in this assay, from the lowest: compound 3; then compound 1; then compound 2.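

With the result for compound 3, this position proves far more sensitive than the first pair could show: in this assay, fluoro in place of carbamoyl on an aromatic carbon, para to a large group, gives a 25-fold lower number from compound 2 to compound 3 (1.40 log units; beyond the scatter) as a large step. Fluoro is a single atom with no hydrogen-bond donor or acceptor, so neither the three heavy atoms of carbamoyl nor its donor and acceptor are needed for a low number here. The comparison with the more elaborate ring also favours the simple one, with a 2.5-fold lower number from compound 1 to compound 3 (0.40 log units; beyond the scatter) on replacing 4-acetyl-3-methoxyphenyl by 4-fluorophenyl, so the acetyl and methoxy groups are not needed either.

No measurement here explains why the number falls with fluoro. From the compounds shown here alone, it also remains open whether a chloro group, an amine or a carboxylic acid at the same place would give a number nearer that of compound 3 or that of compound 2.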